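From a Cyanophenyl Group to Thiophene: an Expected Value

The source may hold more compounds than are shown below. What is called first, only, known or untested is meant among the compounds shown, and "the series" means these compounds.

Compound 1 `COc1cc(N)c(Cl)cc1NC(=O)C1CCN(Cc2cccc(C)c2)CC1` and compound 2 `COc1cc(N)c(Cl)cc1NC(=O)C1CCN(Cc2cccc(C#N)c2)CC1` share one core and differ only in the group attached to the saturated chain carbon bound to the ring amine nitrogen. In a functional assay on the whole organism for antagonist activity, with Mus musculus as the target (a higher number here means that more compound is needed for the effect, a lower number that less compound is needed), compound 1 gives 2.4 mg/kg. On these data alone, for compound 2 this assay reports only a limit, > 4 mg/kg, so its exact position is unknown; (the limit of > 4 mg/kg in this assay, at which 1 of the 2 values shown sits). Among the compounds with values here, the one measured step, an at least 1.6-fold higher number from compound 1 to compound 2 (0.22 log units; that floor lies within the scatter), shows that a change at this position moved the number, though its floor sits within the scatter.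

Compound 3 `COc1cc(N)c(Cl)cc1NC(=O)C1CCN(Cc2ccsc2)CC1` carries the change (thiophen-3-yl in place of 3-cyanophenyl on a saturated chain carbon bound to an amine nitrogen in a ring). Within the data shown here, no measured step covers this exchange. For compound 2 this assay gives only a limit. Compound 1, with a small carbon group at the same place, gives 2.4 mg/kg, and the expectation rests on that value. A thiophen-3-yl group is closer in size to the methylphenyl of compound 1 than to the 3-cyanophenyl of compound 2, so compound 3 is expected to land near compound 1, with an estimated value of 3 mg/kg, ranging from 1.2 mg/kg to 8 mg/kg. This estimated step, an at least 1.3-fold lower number from compound 2 to compound 3 (0.12 log units; that floor lies within the scatter), is uncertain because compound 2 sits at > 4 mg/kg, a limit.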

Compound 3, dose for half-maximal effect: 3.4 mg/kg
For compound 3 the middle estimate is 1.1-fold (0.05 log units) below the measured one, within the range that was stated.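

In this assay, the exchange of 3-methylphenyl for thiophen-3-yl gives a 1.4-fold higher number from compound 1 to compound 3 (0.15 log units; within the scatter), so compound 1 and compound 3 cannot be told apart. On a saturated chain carbon bound to an amine nitrogen in a ring, a five-membered aromatic ring with one sulfur atom can therefore stand in for a six-membered aromatic ring of carbon only, and this place now has a second exact value rather than one exact value and a limit. The exchange of 3-cyanophenyl for thiophen-3-yl gives an at least 1.1-fold lower number from compound 2 to compound 3 (0.07 log units; that floor lies within the scatter), and this can be read only as a floor because compound 2 stands at a limit of the assay, not at a number: the limit of > 4 mg/kg in this assay, at which 1 of the 3 values shown sits.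

On these data alone, how far compound 2 truly lies from compound 1 and compound 3 stays open, and so does whether the nitrile on its ring makes a real difference. All three compounds carry an aromatic ring at this place, so the compounds shown do not tell what an amine, a carboxylic acid or a longer chain would do there.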